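The source may report more compounds than this note shows. Statements on the series, on what has been measured and on what is new or still open speak of the compounds shown alone.

Measured in a functional assay on HL-60 cells (Homo sapiens) for antiproliferative activity, read by MTT assay; a higher number here means a weaker inhibitor, a lower number a stronger inhibitor:
- compound 1 `O[C@@H]1[C@@H](OCc2ccccc2)[C@H](OCc2ccccc2)[C@@H](COCc2ccccc2)O[C@@H]1CC1CCCCC1`: 17200 nM
- compound 2 `O[C@@H]1[C@@H](OCc2ccccc2)[C@H](OCc2ccccc2)[C@@H](COCc2ccccc2)O[C@H]1CC1CCCCC1`: 4100 nM
- compound 3 `CC(C)C[C@@H]1O[C@H](COCc2ccccc2)[C@H](OCc2ccccc2)[C@H](OCc2ccccc2)[C@H]1O`: "not active" (no number reported)

Of the two compounds with a number, compound 2 has the lower one, at 4100 nM, so it is the stronger inhibitor of that pair. The next compound to be tested is compound 4 `CCCCC[C@@H]1O[C@H](COCc2ccccc2)[C@@H](OCc2ccccc2)[C@H](OCc2ccccc2)[C@H]1O`. It carries butyl in place of cyclohexyl on a saturated chain carbon bound to a saturated ring carbon.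

Among the compounds with values here, no measured step changes this group. Within the data shown here, the only measured step, a 4.2-fold lower number from compound 1 to compound 2 (0.62 log units; beyond the scatter), comes with the fact that compounds 1 and 2 differ only in the configuration as drawn, so it shows only how far one small change can move the number. Compound 3, at "not active" (no number reported), adds the risk that an open-chain compound gives no number at all in this assay.

A modest shift towards weaker inhibition is therefore expected, estimated as a 2.2-fold higher number from compound 2 to compound 4 (0.34 log units; beyond the scatter). For compound 4 the estimated value is 9000 nM, with an expected range of 2500 nM to 35000 nM.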

Compound 4, half-maximal inhibitory concentration: "not active" (no number reported)
Compound 4 has no reported number here, and the estimate cannot be compared.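

In this assay, within the data shown here, compound 4 gives "not active" (no number reported) and so no step from compound 2 to compound 4 can be read. The compounds shown leave open how far butyl in place of cyclohexyl moves the number, and whether any compound without cyclohexyl gives a number in this assay at all. Nothing at hand explains this result.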